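A few compounds are considered here, and "the series" means these few. Any claim that something is new, unique, unknown or untested is made for them only; others in the source may bear on it.

Measured in a functional assay on NCI-H1299 cells (Homo sapiens) for cytotoxicity, read by resazurin assay, with a stated time of 72 h; a lower number here means a stronger inhibitor, a higher number a weaker inhibitor:
- compound 1 `COc1cc(/C=C/C(=O)OCCCCOc2no[n+]([O-])c2S(=O)(=O)c2ccccc2)ccc1O`: 420 nM
- compound 2 `O=C(/C=C/c1ccc(OCCCCCO[N+](=O)[O-])c(O)c1)OCCCCCO[N+](=O)[O-]`: > 50000 nM, a limit
- compound 3 `O=C(/C=C/c1ccc(O)c(O)c1)OCc1c(-c2ccccc2)no[n+]1[O-]`: > 50000 nM, a limit

Compound 3 gives no number, only (the limit of > 50000 nM in this assay, at which 2 of the 3 values shown sit). Compound 4 `COc1cc(/C=C/C(=O)OCc2c(-c3ccccc3)no[n+]2[O-])ccc1O` differs from it by methyl in place of hydrogen on an oxygen on an aromatic ring, which turns 3,4-dihydroxyphenyl into 4-hydroxy-3-methoxyphenyl (methyl in place of hydrogen on an oxygen on an aromatic ring). Among the compounds with values here, the 4-hydroxy-3-methoxyphenyl group also occurs in compound 1 at 420 nM, but that compound differs elsewhere as well, so it sets no size for this step. Only a small gain in this assay is expected, and the estimated change is an at least 1.2-fold lower number from compound 3 to compound 4 (0.09 log units; that floor lies within the scatter). The result may again be only a limit. For compound 4 the estimated value is 40000 nM, with an expected range from 15000 nM to 80000 nM.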

Compound 4, half-maximal inhibitory concentration: 12900 nM
The estimate for compound 4 lay 3.1-fold (0.49 log units) above the measured number; measured number below the stated range.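

In this assay, within the data shown here, turning 3,4-dihydroxyphenyl into 4-hydroxy-3-methoxyphenyl gives an at least 3.8-fold lower number from compound 3 to compound 4 (0.58 log units; beyond the scatter), the first size for this change at this position. Compound 3 holds only a limit, so that step is a floor: the limit of > 50000 nM in this assay, at which 2 of the 4 values shown sit.

Compound 1 carries the same 4-hydroxy-3-methoxyphenyl group and gives 420 nM, but it differs elsewhere as well, so that value says nothing about this step alone. The compounds shown leave open whether ethoxy on that oxygen would go further than methoxy. They also leave open whether the same step holds on the core of compound 1.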